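This account rests on a few compounds, and the source may have more. Where it says the series, first, only, none or still open, it means among the compounds named here.

Three compounds sharing one core were measured in an assay on HEK293 cells for displacement of a labelled ligand from 5-hydroxytryptamine receptor 6 (Homo sapiens), with a stated time of 60 min, tested at 0.01 uM, in the presence of a further agent that is not named here; a lower number here means a weaker effect, a higher number a stronger effect of the compound at the concentration tested. Compound 2 `COc1cc(N)c(Cl)cc1C(=O)CCC1CCN(CCNS(=O)(=O)c2cc(Br)c(N)c(Br)c2)CC1` gives 52%, the higher of the two reported numbers. Compound 3 `COc1cc(N)c(Cl)cc1C(=O)CCC1CCN(CCNS(=O)(=O)c2ccc(OC)c(N3CCN(C)CC3)c2)CC1` gives 4%, a value clearly below that of compound 2, and compound 1 `COc1ccc(S(=O)(=O)NCCCN2CCC(CCC(=O)c3cc(Cl)c(N)cc3OC)CC2)cc1` is reported as "not active" (no number reported). Compound 4 `COc1cc(N)c(Cl)cc1C(=O)CCC1CCN(CCNS(=O)(=O)c2ccc(N)c(Br)c2)CC1` has not yet been measured. It differs from compound 2 in one place: hydrogen in place of bromo on an aromatic carbon. Among the compounds with values here, no pair of measured compounds shows this change on its own, so the size of the step cannot be read from the data. The expected step for compound 4 in this assay is estimated at a number 17 percentage points lower from compound 2 to compound 4 (beyond the scatter), downward, though with real uncertainty. Compound 4 is expected to give 35%, within a range from 10% to 60%.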

Compound 4, a percentage reported as inhibition, at one concentration (the size of the read-out at that concentration, not a potency): 39%
Beside the measured number, compound 4's estimate is 4 percentage points below it, and the stated range covers the measured number.
By their numbers in this assay, from the lowest: compound 3; then compound 4; then compound 2.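

In this assay, within the data shown here, going from 4-amino-3,5-dibromophenyl to 4-amino-3-bromophenyl costs only a modest part of the effect (a number 13 percentage points lower from compound 2 to compound 4 (beyond the scatter)), the first direct reading of this position. With hydrogen in place of bromo, compound 4 still keeps a clear effect at the concentration tested, so this bromo is not required for it. Nothing measured here accounts for the step.

The compounds shown leave open what the remaining bromo contributes, since 4-aminophenyl does not appear among them. They also leave open whether a methyl or a nitrile at this position would match bromo or hydrogen.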